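Three Fluorines in Place of One on the Pendant Ring

The source may report more compounds than this note shows. Statements on the series, on what has been measured and on what is new or still open speak of the compounds shown alone.

Among the compounds with values here, compound 1 `CC1(C)c2[nH]nc(NC(=O)c3ccccc3)c2CN1Cc1ccccc1F` gives 450 nM in an assay on Sf21 cells for inhibition of high affinity nerve growth factor receptor (Homo sapiens), read by HTRF, with a stated time of 30 min, in the presence of a further agent that is not named here (on this read-out higher numbers stand for weaker inhibition and lower numbers for stronger inhibition), the lowest of the two numbers measured so far. Compound 2 `CC1(C)c2[nH]nc(NC(=O)c3ccccc3)c2CN1Cc1cc(C(F)(F)F)cc(C(F)(F)F)c1` gives 16400 nM in this assay, a gap well beyond the usual scatter. Compound 3 `CC1(C)c2[nH]nc(NC(=O)c3ccccc3)c2CN1Cc1cc(F)c(F)c(F)c1` is not yet measured; it differs from compound 1 by 3,4,5-trifluorophenyl in place of 2-fluorophenyl on a saturated chain carbon bound to an amine nitrogen in a ring. Within the data shown here, no single-change step between measured compounds exists, so the expectation leans on compound 2, whose value 16400 nM shows how much weaker inhibition a change at this place can bring. A moderate rise in the number, toward weaker inhibition, is expected: a 4.4-fold higher number from compound 1 to compound 3 (0.65 log units; beyond the scatter). Compound 3 is estimated at 2000 nM, with a range from 600 nM to 8000 nM.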

Compound 3, half-maximal inhibitory concentration: 6960 nM
The estimate for compound 3 lay 3.5-fold (0.54 log units) below the measured number; the measured number falls inside the stated range.
By their numbers in this assay, from the lowest: compound 1; then compound 3; then compound 2.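

Replacing 2-fluorophenyl with 3,4,5-trifluorophenyl gives a 15-fold higher number from compound 1 to compound 3 (1.19 log units; beyond the scatter), so inhibition at this position can fall sharply even when the pendant ring gains only fluorine atoms and no trifluoromethyl group. The aromatic carbon ring itself stays the same, which ties this loss to the fluorine substitution on it. Nothing measured here explains the loss.

The change alters both the number of fluorines and where they sit, and the compounds shown cannot separate these two effects. On these data alone, how a plain phenyl ring, or one carrying a methoxy group, would compare remains open.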